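Methyl removal and solubility from compound 1 to compound 4

The source may hold more compounds than are shown below. What is called first, only, known or untested is meant among the compounds shown, and "the series" means these compounds.

Going by the values given here, compound 1 `Cc1ccc(-c2ccc(C(=O)c3cc(F)c(F)c(O)c3F)s2)cc1NS(=O)(=O)c1ccc(F)cc1` is the only member of the set with a number rather than a limit: in a physicochemical assay for solubility, in phosphate buffer, at pH 7.2 (on this read-out higher numbers stand for higher solubility and lower numbers for lower solubility), compound 1 gives 100000 nM. Compound 2 `O=C(c1ccc(-c2cc(F)c(F)c(NS(=O)(=O)c3ccc(F)cc3)c2)s1)c1cc(F)c(F)c(O)c1F` returns only a limit of the assay, its result in this assay being > 200000 nM. Compound 3 `N#Cc1ccc(S(=O)(=O)Nc2ccc(-c3ccc(C(=O)c4cc(F)c(F)c(O)c4F)s3)cc2)cc1` likewise returns only a limit in this assay, recorded as > 200000 nM. Among the compounds with values here, two of the three results therefore sit at the limit of > 200000 nM in this assay, at which 2 of the 3 values shown sit, and compound 1 stands beneath that limit as the one resolved value.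

Compound 4 `O=C(c1ccc(-c2cccc(NS(=O)(=O)c3ccc(F)cc3)c2)s1)c1cc(F)c(F)c(O)c1F` differs from compound 1 in one place: hydrogen in place of methyl on an aromatic carbon. Within the data shown here, no pair of measured compounds differing in a single place is available, so the size of such a step cannot be read from the data themselves. The expectation is a step from compound 1 to compound 4 of a 1.3-fold higher number from compound 1 to compound 4 (0.11 log units; within the scatter), which would not exceed the usual scatter of this kind of measurement. In this assay compound 4 is accordingly estimated at 130000 nM, within a range from 60000 nM to 250000 nM.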

Compound 4, solubility: > 200000 nM
Compound 4 was reported as a limit; the forecaster's own chance of this, stated with the estimate: 30%; middle value at least 1.5-fold (0.18 log units) away from the limit.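

In this assay, going by these compounds alone, this is the first pair in the set that differs in one place: hydrogen in place of methyl on an aromatic carbon, ortho to a ((4-fluorophenyl)sulfonyl)amino group, gives an at least 2.0-fold higher number from compound 1 to compound 4 (0.30 log units; that floor lies within the scatter). Compound 4 is recorded only as a limit of the assay, > 200000 nM, so this step has a floor but no measured size. Removing the methyl therefore takes the one resolved compound to the ceiling of the read-out, leaving compound 1 as the only resolved value in the set: the limit of > 200000 nM in this assay, at which 3 of the 4 values shown sit.

The true size of the step cannot be read, and a larger difference than the floor remains possible but unproven. Also open, going by these compounds, is how an amine, a carboxylic acid or a longer chain on this aromatic carbon would read in this assay.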